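Series at the stability limit; pyridinyl to cyclopropylmethyl

The source may report more compounds than this note shows. Statements on the series, on what has been measured and on what is new or still open speak of the compounds shown alone.

The compounds share one core, carried here by compound 1 `CS(=O)(=O)Nc1ccc2c(c1)S(=O)(=O)N=C(C1=C(O)C3CCCC3N(Cc3ccccn3)C1=O)N2`. In an in vitro ADME assay on microsomes from liver (Homo sapiens) for metabolic stability (on this read-out lower numbers stand for a shorter-lived compound and higher numbers for a longer-lived compound), compound 1 gives > 1 h, which is a limit of the assay and not a number. Compound 2 `Cc1cc(CN2C(=O)C(C3=NS(=O)(=O)c4cc(NS(C)(=O)=O)ccc4N3)=C(O)[C@H]3CCC[C@H]32)ccc1F` in this assay gives > 1 h, again a limit. Compound 3 `CS(=O)(=O)Nc1ccc2c(c1)S(=O)(=O)N=C(C1=C(O)[C@@H]3CCCC[C@@H]3N(Cc3ccc(F)cc3)C1=O)N2` in this assay gives > 1 h, also a limit. Compound 1 therefore stands where every shown compound stands, because the limit of > 1 h in this assay, at which 3 of the 3 values shown sit, leaves no room to place it higher or lower than compound 2 or compound 3.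

Compound 4 `CS(=O)(=O)Nc1ccc2c(c1)S(=O)(=O)N=C(C1=C(O)C3CCCC3N(CCC3CC3)C1=O)N2` is not yet measured. It differs from compound 1 by cyclopropylmethyl in place of pyridin-2-yl on a saturated chain carbon bound to an amide-type nitrogen in a ring. Among the compounds with values here, no pair of measured compounds differing in one place is available, so no measured step is known in this assay.

The expected step that the limit leaves unreadable from compound 1 to compound 4 is none beyond the usual scatter, since every value shown in this assay sits at the same limit. Compound 4 is expected to give 1.5 h in this assay, with a range from 0.5 h to 4 h, most likely again reported only as a limit.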

Compound 4, half-life: 0.417 h
Estimate against measurement, compound 4: 3.6-fold (0.56 log units) above; the whole stated range lies above it.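

In this assay, cyclopropylmethyl in place of pyridin-2-yl on a saturated chain carbon bound to an amide-type nitrogen in a ring gives an at least 2.3-fold lower number from compound 1 to compound 4 (0.37 log units; beyond the scatter). Within the data shown here, with 0.417 h, compound 4 is the first compound with a number rather than a limit, so this position can move the read-out on the core of compound 1. The step is only a minimum, because the value for compound 1 is a limit: the limit of > 1 h in this assay, at which 3 of the 4 values shown sit.

The compounds shown leave open whether the step follows from losing pyridin-2-yl or from gaining cyclopropylmethyl; an unsubstituted phenyl or a straight butyl chain at the same place on the core of compound 1 would separate the two. As far as these compounds go, how far the half-life of compound 1 extends beyond its limit also stays open.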